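Benzyl in Place of tert-Butyl: Compound 2 to Compound 4

The source may report more compounds than this note shows. Statements on the series, on what has been measured and on what is new or still open speak of the compounds shown alone.

Compound 1 `COC(C)(C)[C@@H](O)C(=O)N1[C@H](C(=O)NCc2cc(Cl)ccc2-n2cnnn2)C[C@@H]2C[C@@H]21` gives 40 mL.min-1.g-1 in an ADME assay on liver for metabolic stability, with Liver microsome (Homo sapiens) as the target, read by LC-MS, using microsomes; on this read-out lower numbers stand for slow clearance and higher numbers for fast clearance. Compound 3 `CC(C)(C)OC[C@@H](O)C(=O)N1[C@H](C(=O)NCc2cc(Cl)ccc2-n2cnnn2)C[C@@H]2C[C@@H]21` gives 21 mL.min-1.g-1. Compound 2 `CC(C)(C)[C@@H](O)C(=O)N1N=CC[C@H]1C(=O)NCc1cc(Cl)ccc1-n1cnnn1` gives < 12 mL.min-1.g-1, which is a limit of the assay rather than a number.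

Compound 2 therefore stands at the limit of < 12 mL.min-1.g-1 in this assay, at which 1 of the 3 values shown sits. Compound 4 `O=C(NCc1cc(Cl)ccc1-n1cnnn1)[C@@H]1CC=NN1C(=O)[C@H](O)Cc1ccccc1` differs from compound 2 in one place: benzyl in place of tert-butyl on a saturated chain carbon bound to a carbonyl carbon and an oxygen on a saturated carbon. Within the data shown here, no measured step covers this exchange. Among the measured compounds shown here, the only measured step, a 1.9-fold lower number from compound 1 to compound 3 (0.28 log units; within the scatter), alters a different group at the same place and stays within the scatter, so it gives no direction for the present change. The expected step is an at least 1.6-fold higher number from compound 2 to compound 4 (0.22 log units; that floor lies within the scatter), stated with low confidence. Compound 4 is expected to give about 20 mL.min-1.g-1, within a range from 8 mL.min-1.g-1 to 50 mL.min-1.g-1.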

Compound 4, intrinsic clearance in microsomes: < 12 mL.min-1.g-1
Compound 4 ended at the assay's limit; the forecaster's own chance of this, stated with the estimate: 30%; middle value at least 1.6-fold (0.22 log units) away from the limit.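

Among these compounds, compound 2 and compound 4 both end at a limit, so the exchange between them gives no step that can be read: the limit of < 12 mL.min-1.g-1 in this assay, at which 2 of the 4 values shown sit. In this assay the compounds shown leave open whether benzyl in place of tert-butyl alters clearance at all.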